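Piperazine Amide to Methyl Ester on a Shared Core

The source may hold more compounds than are shown below. What is called first, only, known or untested is meant among the compounds shown, and "the series" means these compounds.

Compound 1 `CN1CCN(C(=O)/C=C/c2ccncc2-c2ccc3ccccc3c2)CC1`: > 30000 nM
Compound 2 `O=C(/C=C/c1ccncc1-c1ccc2[nH]ccc2c1)N1CCOCC1`: "not determined" (no result reported)
Compound 3 `Cn1ncc2cc(-c3cnccc3/C=C/C(=O)O)ccc21`: > 30000 nM

These three compounds were examined in a functional assay on HCT-116 cells (Homo sapiens) for inhibition, read by MTT assay, with a stated time of 72 h; on this read-out higher numbers stand for weaker inhibition of growth and lower numbers for stronger inhibition of growth. In this assay compound 1 gives > 30000 nM, and that value is a limit of the assay rather than a number. Compound 3 gives > 30000 nM, which is again a limit. For compound 2 the outcome is "not determined" (no result reported). Compound 1 therefore stands at the limit, as does compound 3, a point summarised by the limit of > 30000 nM in this assay, at which 2 of the 3 values shown sit. No measured step between any two of these compounds is available, so the data give no direction at all.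

Compound 4 `COC(=O)/C=C/c1ccncc1-c1ccc2ccccc2c1` is the compound still to be measured. It differs from compound 1 in a single place: methoxy in place of 4-methylpiperazin-1-yl on a carbonyl carbon. Within the data shown here, with no measured step to lean on, the only anchor is the limit at which compound 1 sits. The step of a number no higher from compound 1 to compound 4 (the limit leaves the size open) is expected to be no larger than the usual scatter, in no preferred direction. The estimate for compound 4 in this assay is 30000 nM, within a range from 5000 nM to 100000 nM, with a real chance that only a limit is reported again.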

Compound 4, concentration for 50% growth inhibition: 350 nM
Beside the measured number, compound 4's estimate is 86-fold (1.93 log units) above it; the measured number lies below the stated range.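

Replacing 4-methylpiperazin-1-yl with methoxy on a carbonyl carbon gives an at least 85-fold lower number from compound 1 to compound 4 (1.93 log units; beyond the scatter) in this assay, and a lower number here means stronger inhibition of growth. This is the first measured step among these compounds, and it shows that the group on this carbonyl carbon can separate a compound with a measurable growth-inhibition value from one that reaches only the assay's limit. The full size of the step cannot be read because compound 1 has a limit and not a number, the same kind of result that recurs in this small set: the limit of > 30000 nM in this assay, at which 2 of the 4 values shown sit.

The single change removes the piperazine ring and also turns an amide into an ester, so the compounds shown do not reveal which of these differences matters more. An ethoxy group, a dimethylamino group or a hydroxyl group in the same place on the core of compound 4, the last of these giving a carboxylic acid, would help to separate the size of the group from the type of carbonyl compound.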